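The source may report more compounds than this note shows. Statements on the series, on what has been measured and on what is new or still open speak of the compounds shown alone.

Measured compounds:
compound 1 `COc1ccc2cc(-c3ccccc3)c(O)nc2c1`: 10000 nM
compound 2 `CCOC(=O)Cn1c(=O)c(-c2ccc(OC)cc2)cc2c(OC)cc(OC)cc21`: 10000 nM

In a functional assay on PC-3 cells (Homo sapiens) for cytotoxicity, read by colorimetric assay and MTT assay (on this read-out lower numbers stand for stronger inhibition and higher numbers for weaker inhibition), compound 1 gives 10000 nM and compound 2 gives 10000 nM; compound 2 stands level with compound 1 at the digits shown, within the scatter. Compound 3 `CCN(CC)C(=O)CCn1c(=O)c(-c2ccc(OC)cc2)cc2c(OC)cc(OC)cc21` differs from compound 2 by (diethylcarbamoyl)methyl in place of ethoxycarbonyl on a saturated chain carbon bound to an aromatic nitrogen. For the measured compounds named here, no step between measured compounds bears on this change, so the expected step of no change at the digits printed from compound 2 to compound 3 (within the scatter) from compound 2 to compound 3 in this assay is none beyond the scatter. Compound 3 is therefore estimated at 10000 nM in this assay, within a range of 4000 nM to 25000 nM.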

Compound 3, half-maximal inhibitory concentration: 10000 nM
Estimate against measurement, compound 3: no gap at the digits printed, within the range that was stated.
By their numbers in this assay, from the lowest: compounds 1, 2 and 3 (each within the scatter of the next).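

In this assay, for the compounds shown here, the exchange of ethoxycarbonyl for (diethylcarbamoyl)methyl on a saturated chain carbon bound to an aromatic nitrogen gives no change at the digits printed from compound 2 to compound 3 (within the scatter) and is the only step read at this position so far. It shows that this place takes the larger group with its longer chain and the value stays level. Nothing measured here offers a reason for this result.
From the compounds shown here alone, whether an amine or a carboxylic acid at the end of this chain would move the value stays open, and so does the effect of a shorter chain.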